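The source may hold more compounds than are shown below. What is called first, only, known or untested is meant among the compounds shown, and "the series" means these compounds.

In a functional assay with Oryctolagus cuniculus as the target (on this read-out higher numbers stand for weaker inhibition and lower numbers for stronger inhibition), compound 3 `COc1ccc(-c2nc(CNC(=O)c3cccnc3)sc2-c2ccc(OC)cc2)cc1` gives 25 nM, and compound 1 `COc1ccc(-c2nc(/N=C(\N)N(C)C)sc2-c2ccc(OC)cc2)cc1` gives 37 nM. These two values lie within the scatter of each other, as a 1.5-fold lower number from compound 1 to compound 3 (0.17 log units; within the scatter) shows. Compound 2 `COc1ccc(-c2nc(CN)sc2-c2ccc(OC)cc2)cc1` is reported only as a limit, > 100 nM.

Compound 4 `CNC(=O)NCc1nc(-c2ccc(OC)cc2)c(-c2ccc(OC)cc2)s1` carries methylamino in place of pyridin-3-yl on a carbonyl carbon, so (pyridin-3-yl)carbonyl becomes methylcarbamoyl. Within the data shown here, no measured step makes this exchange directly. The closest evidence is an at least 4.0-fold lower number from compound 2 to compound 3 (0.60 log units; beyond the scatter), which removes the whole (pyridin-3-yl)carbonyl from compound 3 and ends at the limit of compound 2. an at least 2.7-fold higher number from compound 1 to compound 2 (0.43 log units; beyond the scatter) also ends at that limit. Compound 4 keeps the carbonyl on the amine nitrogen and loses only the pyridin-3-yl, so a smaller change than an at least 4.0-fold lower number from compound 2 to compound 3 (0.60 log units; beyond the scatter) is expected, towards a higher number in this assay. The expected change is a 1.8-fold higher number from compound 3 to compound 4 (0.26 log units; within the scatter), a modest one that may not clear the scatter. For compound 4 the estimated value is 45 nM, with an expected range of 15 nM to 130 nM.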

Compound 4, half-maximal inhibitory concentration: 22 nM
Compound 4: middle estimate off by 2.0-fold (0.31 log units), on the high side; the range from low to high includes it.
By their numbers in this assay, from the lowest: compounds 4, 3 and 1 (each within the scatter of the next). At a limit, above all of these: compound 2.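

In this assay, the exchange of pyridin-3-yl for methylamino on the carbonyl carbon stays within the scatter (a 1.1-fold lower number from compound 3 to compound 4 (0.06 log units; within the scatter)), so in these compounds the aromatic ring is not needed for a value in this range. On the amine nitrogen, methylcarbamoyl gives a step beyond the scatter (an at least 4.5-fold lower number from compound 2 to compound 4 (0.65 log units; beyond the scatter)), so the gain that compound 3 showed with (pyridin-3-yl)carbonyl is also seen with a second, ring-free carbonyl group. The remaining comparison also stays within the scatter (a 1.7-fold lower number from compound 1 to compound 4 (0.23 log units; within the scatter)), which puts the ring-free group of compound 4 level with the quite different group of compound 1.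

The compounds shown leave open whether the carbonyl itself is required, or whether a longer chain such as butylamino on it would hold the value. The full size of the steps from compound 2 also stays open, as its value is a limit and not a number: the limit of > 100 nM in this assay, at which 1 of the 4 values shown sits.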